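Swapping Aryl Groups on a Cytotoxicity Core

A few compounds are considered here, and "the series" means these few. Any claim that something is new, unique, unknown or untested is made for them only; others in the source may bear on it.

Compound 1 `COc1ccc(-c2nc(C)c(C(=O)CSc3nc(-c4ccc(Cl)cc4)c(C#N)c(=O)[nH]3)s2)cc1` and compound 2 `COc1ccc(-c2nc(C)c(C(=O)CSc3nc(-c4cccc(OC)c4)c(C#N)c(=O)[nH]3)s2)cc1` share a core and differ in one place: 3-methoxyphenyl in place of 4-chlorophenyl on an aromatic carbon. In an ADME assay on HEK293 cells (Homo sapiens) for cytotoxicity, read by MTT assay, with a stated time of 48 h (a higher number here means a weaker inhibitor, a lower number a stronger inhibitor), compound 1 gives 63000 nM, and compound 2 gives 95400 nM. That change produced a 1.5-fold higher number from compound 1 to compound 2 (0.18 log units; within the scatter). Compound 3 `Cc1nc(-c2ccc(Cl)cc2)sc1C(=O)CSc1nc(-c2ccc(Cl)cc2)c(C#N)c(=O)[nH]1` carries a different core, the difference being (chloro in place of methoxy on an aromatic carbon). In this assay compound 3 gives 75100 nM, and its step from compound 1 is a 1.2-fold higher number from compound 1 to compound 3 (0.08 log units; within the scatter). Compound 4 `COc1cccc(-c2nc(SCC(=O)c3sc(-c4ccc(Cl)cc4)nc3C)[nH]c(=O)c2C#N)c1` has not yet been tested. It differs from compound 3 by 3-methoxyphenyl in place of 4-chlorophenyl on an aromatic carbon, the same change as from compound 1 to compound 2, made around the same place. Because the earlier change gave only a 1.5-fold higher number from compound 1 to compound 2 (0.18 log units; within the scatter), a similarly small step is expected here: a 1.3-fold higher number from compound 3 to compound 4 (0.12 log units; within the scatter). Compound 4 is therefore estimated at 100000 nM, with a likely range from 50000 nM to 200000 nM.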

Compound 4, half-maximal inhibitory concentration: 77900 nM
Compound 4: middle estimate off by 1.3-fold (0.11 log units), on the high side, and the stated range covers the measured number.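

Putting 3-methoxyphenyl in place of 4-chlorophenyl gave a 1.0-fold higher number from compound 3 to compound 4 (0.02 log units; within the scatter) in this assay, and this agrees with the same change on the other core: the same change on two cores in this assay, a 1.5-fold higher number (0.18 log units; within the scatter) from compound 1 to compound 2 and a 1.0-fold higher number (0.02 log units; within the scatter) from compound 3 to compound 4, 1.5-fold (0.16 log units) apart, within the scatter of two such steps. Putting chloro in place of methoxy gave a 1.2-fold lower number from compound 2 to compound 4 (0.09 log units; within the scatter), and this also agrees with its earlier counterpart: the same change on two cores in this assay, a 1.2-fold higher number (0.08 log units; within the scatter) from compound 1 to compound 3 and a 1.2-fold lower number (0.09 log units; within the scatter) from compound 2 to compound 4, 1.5-fold (0.16 log units) apart, within the scatter of two such steps. All of these steps lie within the scatter, which shows that neither change visibly moved the number on either core, but not that a real effect carries from one core to the other.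

The compounds shown leave open whether a different group on the aromatic ring, such as an amine or a carboxylic acid, would give a step beyond the scatter. They also leave open whether such a step would hold across both cores.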